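The compounds below may be only part of what the source reports. "The series", "measured", "known", "first", "only" and "open" are said of these compounds alone.

Measured so far in a functional assay on Vero cells (Chlorocebus sabaeus) for cytotoxicity; a higher number here means a weaker inhibitor, a lower number a stronger inhibitor:

compound 1 `O=c1[nH]c(=O)n(C2C[C@@H](O)[C@@H](CO)O2)nc1/C=C/Cl` — > 500 ug/mL
compound 2 `O=c1[nH]c(=O)n(C2C[C@@H](O)[C@@H](CO)O2)nc1C=C(Br)Br` — > 500 ug/mL
compound 3 `O=Cc1nn(C2C[C@@H](O)[C@@H](CO)O2)c(=O)[nH]c1=O` — 180 ug/mL

For the measured compounds named here, compound 3 gives the only actual number among the three values shown. The value of compound 1 is a limit of the assay, not a number. The value of compound 2 is likewise a limit. Both sit at the limit of > 500 ug/mL in this assay, at which 2 of the 3 values shown sit.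

Compound 4 `COC(=O)/C=C/c1nn(C2C[C@@H](O)[C@@H](CO)O2)c(=O)[nH]c1=O` is the next member to be tested. It differs from compound 3 as follows: 2-(methoxycarbonyl)ethenyl in place of formyl on an aromatic carbon.

Going by the values given here, two measured steps bear on this change, an at least 2.7-fold lower number from compound 1 to compound 3 (0.44 log units; beyond the scatter) and an at least 2.7-fold lower number from compound 2 to compound 3 (0.44 log units; beyond the scatter); in each a two-carbon ethenyl substituent gave way to formyl and the number fell by at least a modest amount. The change to compound 4 runs the other way: formyl leaves and an ethenyl-type group returns, now carrying a methoxycarbonyl. A step of at least modest size toward a higher number is therefore expected in this assay, with a fair chance that compound 4 again reaches only the limit at which compound 1 and compound 2 stand.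

Compound 4 is estimated at 420 ug/mL, between 150 ug/mL and 1200 ug/mL, which would be a step of a 2.3-fold higher number from compound 3 to compound 4 (0.37 log units; beyond the scatter).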

Compound 4, concentration for 50% inhibition: > 500 ug/mL
Compound 4 gave a limit, no number; the forecaster's own chance of this, stated with the estimate: 55%; middle value at least 1.1-fold (0.07 log units) away from the limit.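

In this assay, for the compounds shown here, there is an at least 2.7-fold higher number from compound 3 to compound 4 (0.44 log units; beyond the scatter); the earlier steps away from formyl involved only halogen-bearing ethenyl groups, and this one extends the same direction to an ethenyl group carrying methoxycarbonyl, on the same aromatic carbon. Compound 4 gives > 500 ug/mL, which is a limit of the assay and not a number. Compound 1, compound 2 and compound 4 all carry substituted ethenyl groups and stand at one limit, while compound 3, with formyl, is the exception: the limit of > 500 ug/mL in this assay, at which 3 of the 4 values shown sit.

From the compounds shown here alone, the steps among compound 1, compound 2 and compound 4 cannot be read, and any order among their three ethenyl groups stays unknown. Also open, going by these compounds, is whether a carboxylic acid or an aminomethyl group in place of formyl at this aromatic carbon would give a number in this assay.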